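Thioether aryl-to-benzyl swap on a leukotriene-type acid core

A few compounds are considered here, and "the series" means these few. Any claim that something is new, unique, unknown or untested is made for them only; others in the source may bear on it.

Measured compounds:
compound 1, `COc1ccc(CCCCCCCCOc2ccc(CSc3cccc(C(=O)O)c3)nc2/C=C/C(=O)O)cc1`, gives 550 nM in a functional assay on the whole organism with Homo sapiens as the target, read by calcium flux; on this read-out lower numbers stand for stronger inhibition and higher numbers for weaker inhibition
compound 2, `COc1ccc(CCCCCCCCOc2ccc(C[S+]([O-])c3cccc(C(=O)O)c3)nc2/C=C/C(=O)O)cc1`, gives 3900 nM in this assay
compound 3, `COc1ccc(CCCCCCCCOc2ccc(CS(=O)(=O)Cc3cccc(C(=O)O)c3)nc2/C=C/C(=O)O)cc1`, gives 920 nM in this assay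

Among these three numbers compound 1 has the lowest. Compound 3 sits nearest to it, and the two values lie within the scatter of each other, so no order between them can be claimed. Compound 2 lies furthest away: a 7.1-fold higher number from compound 1 to compound 2 (0.85 log units; beyond the scatter).

Compound 4, `COc1ccc(CCCCCCCCOc2ccc(CSCc3ccc(C(=O)O)cc3)nc2/C=C/C(=O)O)cc1`, has not been measured. It differs from compound 1 at one place: 4-carboxybenzyl in place of 3-carboxyphenyl on a sulfur.

For the measured compounds named here, no measured step covers this change. The step from compound 1 to compound 2 alters the sulfur itself, not the group attached to it, and therefore does not bear on the question. Going by the values given here, the only hint comes from compounds 1 and 3, whose values show that a carboxybenzyl on the sulfur, albeit with a different oxidation state of the sulfur, gives a number within the scatter of compound 1. On that basis compound 4 is expected to stay close to compound 1, with a 1.5-fold higher number from compound 1 to compound 4 (0.16 log units; within the scatter) as the estimated step. Compound 4 is therefore estimated at 800 nM, with a range from 300 nM to 2500 nM.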

Compound 4, half-maximal inhibitory concentration: 175 nM
The estimate for compound 4 lay 4.6-fold (0.66 log units) above the measured number; measured number below the stated range.
By their numbers in this assay, from the lowest: compound 4; then compounds 1 and 3 (each within the scatter of the next); then compound 2.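

In this assay, the group on the sulfur proves able to move the number beyond the scatter with the sulfur left as a thioether: 4-carboxybenzyl in place of 3-carboxyphenyl gives a 3.1-fold lower number from compound 1 to compound 4 (0.50 log units; beyond the scatter). For the compounds shown here, until now, the only step beyond the scatter was the one that altered the sulfur itself, and compound 3, the only earlier compound with a carboxybenzyl group, differs from compound 1 in its sulfur as well as in that group, so it could not isolate this change. The new thioether also stands far from the sulfoxide, with a 22-fold lower number from compound 2 to compound 4 (1.35 log units; beyond the scatter), although nothing measured here explains why either number moves.

The compounds shown leave open whether the step comes from the extra carbon of the benzyl group or from the changed placement of the carboxylic acid, a question that 3-carboxybenzyl or 4-carboxyphenyl on the same sulfur would address. They also leave open whether the carboxylic acid on this ring can give way to a tetrazole, and how a 4-carboxybenzyl group behaves on a sulfone.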